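This account rests on a few compounds, and the source may have more. Where it says the series, first, only, none or still open, it means among the compounds named here.

Compound 1 `Cc1c(C)c2c(c(C)c1O)CCC(C)(COc1ccc(/C=C3\SC(=O)N(C)C3=O)cc1)O2` is the parent of this small set. In an ADME assay on cells (Hepatocyte, Homo sapiens) for cytotoxicity, read by MTT assay, with a stated time of 90 min, tested at 100 uM (on this read-out lower numbers stand for a stronger effect and higher numbers for a weaker effect at the one concentration tested), compound 1 gives 147%. For the measured compounds named here, compound 2 `Cc1c(C)c2c(c(C)c1OC(=O)CCCCCCCN)CCC(C)(COc1ccc(/C=C3\SC(=O)N(C)C3=O)cc1)O2` carries an amine-bearing ester; in this assay compound 2 gives 84.5%, and the step of a number 62.5 percentage points lower from compound 1 to compound 2 (beyond the scatter) is the only one-point change measured so far. Compound 3 `Cc1c(C)c2c(c(C)c1CCCCCCNC(=O)OCc1ccccc1)CCC(C)(COc1ccc(/C=C3\SC(=O)NC3=O)cc1)O2` holds a protected amine on a six-carbon chain and lacks the methyl on the ring nitrogen; in this assay compound 3 gives 85.1%, the second highest of the three numbers, within the scatter of compound 2 and well apart from compound 1.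

Compound 4 `Cc1c(C)c2c(c(C)c1CCCCCCN)CCC(C)(COc1ccc(/C=C3\SC(=O)NC3=O)cc1)O2` differs from compound 3 by hydrogen in place of benzyloxycarbonyl on an amine nitrogen. Going by the values given here, no measured step matches this change directly. The step from compound 1 to compound 2, in which a free amine arrives, was large, yet compound 2 with its free amine and compound 3 with its protected amine sit within the scatter of each other, so no step beyond the scatter is anticipated. The expected step of a number 0.1 percentage points lower from compound 3 to compound 4 (within the scatter) is small. Compound 4 is expected to give 85%, with a range from 65% to 105%.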

Compound 4, a percentage reported as activity, at one concentration (the size of the read-out at that concentration, not a potency): 83.2%
Beside the measured number, compound 4's estimate is 1.8 percentage points above it; the range from low to high includes it.
By their numbers in this assay, from the lowest: compounds 4, 2 and 3 (each within the scatter of the next); then compound 1.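

On the amine nitrogen of the chain, this assay does not separate the benzyloxycarbonyl-bearing compound from its free amine: a number 1.9 percentage points lower from compound 3 to compound 4 (within the scatter). For the compounds shown here, this is the first direct test of this change, and it shows that benzyloxycarbonyl, with its 10 heavy atoms and six-membered aromatic ring of carbon only, can give way to hydrogen with no step beyond the scatter. No available evidence bears on this result.

The compounds shown leave open whether an acetyl group on the same nitrogen, or a carboxylic acid in place of the amine, would read the same way in this assay. They also leave open how a longer chain would read, and whether a methyl on the ring nitrogen would matter in compound 4.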